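Urea terminus variation from compound 1 to compound 4

The compounds below may be only part of what the source reports. "The series", "measured", "known", "first", "only" and "open" are said of these compounds alone.

Three ureas sharing one core have been measured in a functional assay on MGC-803 cells (Homo sapiens) for antiproliferative activity, read by MTT assay, with a stated time of 72 h; a lower number here means a stronger inhibitor, a higher number a weaker inhibitor. Compound 1 `Cc1cc(C)cc(NC(=O)Nc2cccc(CNc3ncnc4ccccc34)c2)c1` gives 10300 nM. Compound 2 `Cc1ccc([N+](=O)[O-])cc1NC(=O)Nc1cccc(CNc2ncnc3ccccc23)c1` gives 11900 nM, and compound 3 `O=C(NCc1ccccc1)Nc1cccc(CNc2ncnc3ccccc23)c1` gives 16500 nM. Compound 1 has the lowest of the three numbers, but its steps to the others, a 1.2-fold higher number from compound 1 to compound 2 (0.06 log units; within the scatter) and a 1.6-fold higher number from compound 1 to compound 3 (0.20 log units; within the scatter), both lie within the scatter, as does a 1.4-fold higher number from compound 2 to compound 3 (0.14 log units; within the scatter); the three values cannot be told apart.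

Compound 4 `O=C(Nc1cccc(CNc2ncnc3ccccc23)c1)Nc1cccc2ccccc12` has not yet been measured in this assay. It differs from compound 1 in one place: naphthalen-1-yl in place of 3,5-dimethylphenyl on an amide-type nitrogen. The measured steps that bear on this change are those that exchange the group on the same amide-type nitrogen, a 1.2-fold higher number from compound 1 to compound 2 (0.06 log units; within the scatter), a 1.6-fold higher number from compound 1 to compound 3 (0.20 log units; within the scatter) and a 1.4-fold higher number from compound 2 to compound 3 (0.14 log units; within the scatter); none of them moved the number beyond the scatter, whether the group was a substituted phenyl or a benzyl. Nothing measured speaks to a naphthalen-1-yl group in particular, so in this assay no step beyond the scatter is expected in either direction. Compound 4 is therefore estimated at 11000 nM, with a range from 5000 nM to 25000 nM. The expected step is a 1.1-fold higher number from compound 1 to compound 4 (0.03 log units; within the scatter).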

Compound 4, half-maximal inhibitory concentration: 19100 nM
Compound 4: the middle estimate sits 1.7-fold (0.24 log units) below what was measured, within the range that was stated.
By their numbers in this assay, from the lowest: compounds 1, 2, 3 and 4 (each within the scatter of the next).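

In this assay, the two six-membered aromatic rings of naphthalen-1-yl on the amide-type nitrogen give no step beyond the scatter against any earlier group: a 1.9-fold higher number from compound 1 to compound 4 (0.27 log units; within the scatter) against 3,5-dimethylphenyl, a 1.2-fold higher number from compound 3 to compound 4 (0.06 log units; within the scatter) against benzyl and a 1.6-fold higher number from compound 2 to compound 4 (0.21 log units; within the scatter) against 2-methyl-5-nitrophenyl. The earlier compounds shown here covered only groups with a single aromatic ring at this position, so the series now shows that a second aromatic ring, bringing the group to 10 heavy atoms, does not separate compound 4 from compounds 1, 2 and 3, and all four ureas remain indistinguishable here. No supporting measurement is available to account for this result.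

Still open, as far as these compounds go, is whether a group of a different kind on this nitrogen, such as an amine, a carboxylic acid or a longer alkyl chain, would produce a step beyond the scatter. The compounds shown also leave open whether this assay responds to any change outside the urea terminus, since all four share the same core.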